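A few compounds are considered here, and "the series" means these few. Any claim that something is new, unique, unknown or untested is made for them only; others in the source may bear on it.

Measured compounds:
compound 1 `CCOC(=O)C[C@H]1[C@@H](O[Si](C)(C)C(C)(C)C)[C@H](n2cnc3c(NC(=O)Nc4ccccc4)ncnc32)O[C@@H]1COC(=O)NC` with 4.65 nM
compound 2 `CNC(=O)NC[C@H]1O[C@@H](n2cnc3c(NC(=O)Nc4ccccc4)ncnc32)[C@H](O[Si](C)(C)C(C)(C)C)[C@@H]1CC(=O)N(C)OC` with 3.87 nM

Both were tested in a functional assay on A498 cells (Homo sapiens) for antiproliferative activity; a lower number here means a stronger inhibitor of growth, a higher number a weaker inhibitor of growth. Compound 2 gives the lowest of the two numbers, and compound 1 stands nearest to it with a difference that is within the usual scatter of this assay, so the two compounds cannot be told apart on these numbers. Within the data shown here, no pair of compounds differing in a single place has been measured, so no single step of known size exists yet.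

Compound 3 `CCOC(=O)C[C@H]1[C@@H](O[Si](C)(C)C(C)(C)C)[C@H](n2cnc3c(NC(=O)Nc4ccccc4)ncnc32)O[C@@H]1CNC(=O)NC` has not been measured. It differs from compound 2 in one place: ethoxy in place of methoxy(methyl)amino on a carbonyl carbon. Compound 1 already carries the ethoxy group on that carbonyl carbon and shows a number within the scatter of compound 2, which suggests that this exchange on its own does not shift the number far. In this assay the step from compound 2 to compound 3 is therefore expected to be small, in no particular direction, and not beyond the scatter: a 1.2-fold higher number from compound 2 to compound 3 (0.07 log units; within the scatter). Compound 3 is estimated to give 4.5 nM, with a range from 2 nM to 10 nM.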

Compound 3, concentration for 50% growth inhibition: 3.34 nM
Compound 3: the middle estimate sits 1.3-fold (0.13 log units) above what was measured; the measured number falls inside the stated range.
By their numbers in this assay, from the lowest: compounds 3, 2 and 1 (each within the scatter of the next).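

In this assay, among these compounds, compound 3 turns what had only been inferred from compounds 1 and 2, which differ in two places at once, into a direct reading: the single exchange on a carbonyl carbon leaves the number within the scatter (a 1.2-fold lower number from compound 2 to compound 3 (0.06 log units; within the scatter)). Compound 3 also isolates a second exchange, (methylcarbamoyl)amino in place of (methylcarbamoyl)oxy on a saturated chain carbon bound to a saturated ring carbon, and that step is also within the scatter (a 1.4-fold lower number from compound 1 to compound 3 (0.14 log units; within the scatter)), so at this level of precision neither single change can be told from no change in this assay. Nothing available here explains why either exchange leaves the number within the scatter.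

From the compounds shown here alone, it remains open whether the number would hold with a carboxylic acid, a primary amide or a longer chain in place of the ethoxycarbonyl group, since all three compounds keep a carbonyl at this place. Also open, going by these compounds, is how a free hydroxyl group would compare with the tert-butyldimethylsilyloxy group that all three compounds carry on the shared core.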